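A Stereocentre Left Undefined on a Dihydroxypropyl Chain

A few compounds are considered here, and "the series" means these few. Any claim that something is new, unique, unknown or untested is made for them only; others in the source may bear on it.

Of the compounds shown here, three with a shared core have been measured in a functional assay on MDA-MB-231 cells (Homo sapiens) for cytotoxicity, read by MTT assay, with a stated time of 72 h; on this read-out lower numbers stand for stronger inhibition and higher numbers for weaker inhibition. Compound 1 `O=C1c2c[n+]([O-])c3ccccc3c2C(=O)c2c1c1ccccc1n2CCCCn1ccnc1` gives 210 nM, compound 2 `O=C1c2c[n+]([O-])c3ccccc3c2C(=O)c2c1c1ccccc1n2Cc1cn([C@@H]2C[C@H](O)[C@@H](CO)O2)nn1` gives 130 nM and compound 3 `O=C1c2c[n+]([O-])c3ccccc3c2C(=O)c2c1c1ccccc1n2Cc1cn(C[C@H](O)CO)nn1` gives 1310 nM, the highest number and so the weakest result of the three.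

Compound 4 `O=C1c2c[n+]([O-])c3ccccc3c2C(=O)c2c1c1ccccc1n2Cc1cn(CC(O)CO)nn1` differs from compound 3 only in how it is drawn: the two compounds have the same atoms and bonds; at least one stereo element is drawn with a configuration in one of them and without one in the other: 1 of 1 stereo elements differ; a stereocentre at a saturated chain carbon is drawn S in compound 3 and without a configuration in compound 4. A stereocentre is an atom whose groups can be arranged in mirror-image ways, and the drawing of compound 4 does not say which arrangement is present.

Two measured steps lead to compound 3. Putting 1-(2,3-dihydroxypropyl)-1H-1,2,3-triazol-4-yl in place of 3-(1H-imidazol-1-yl)propyl gave a 6.2-fold higher number from compound 1 to compound 3 (0.80 log units; beyond the scatter), and putting 2,3-dihydroxypropyl in place of 4-hydroxy-5-(hydroxymethyl)oxolan-2-yl gave a 10-fold higher number from compound 2 to compound 3 (1.00 log units; beyond the scatter). Going by the values given here, both exchange whole groups, whereas no atom or bond changes here, and no measured pair tests a configuration alone. Their size therefore does not carry over, and no step beyond the scatter is expected in this assay.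

The best guide is compound 3 itself, at 1310 nM. The expected step is a 1.0-fold lower number from compound 3 to compound 4 (0.00 log units; within the scatter). For compound 4 the estimated value is 1300 nM, with an expected range from 700 nM to 2500 nM.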

Compound 4, half-maximal inhibitory concentration: 1290 nM
Compound 4: the middle estimate sits 1.0-fold (0.00 log units) above what was measured; the measured number falls inside the stated range.
By their numbers in this assay, from the lowest: compounds 2 and 1 (each within the scatter of the next); then compounds 4 and 3 (each within the scatter of the next).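

In this assay, going by these compounds alone, the two drawings give results that cannot be told apart, with a 1.0-fold lower number from compound 3 to compound 4 (0.01 log units; within the scatter), and this is the first pair here that touches the drawn configuration and nothing else. This pair therefore isolates a single point, the stereocentre on the 2,3-dihydroxypropyl chain: the fact that one of compounds 3 and 4 is drawn with a defined configuration and the other without, at the place where they differ

The larger gaps also appear with the undefined drawing, with a 9.9-fold higher number from compound 2 to compound 4 (1.00 log units; beyond the scatter) and a 6.1-fold higher number from compound 1 to compound 4 (0.79 log units; beyond the scatter), so they go with the exchange of groups and do not depend on the S configuration being drawn at this carbon.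

Whether the configuration at this carbon matters stays open: the drawing of compound 4 does not say which arrangement or arrangements are present, and no compound shown is drawn with the R configuration there. Also open, on these data alone, is how an amine or a carboxylic acid in place of the hydroxyl groups on this chain would read in this assay.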